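Placing 3-Chlorophenyl on the Chain Carbon of Compound 1

The compounds below may be only part of what the source reports. "The series", "measured", "known", "first", "only" and "open" are said of these compounds alone.

Compound 1 `NCC(=O)Nc1cc2cc[nH]c(=O)c2cc1Cl`: 120 nM
Compound 2 `O=C(Nc1cc2cc[nH]c(=O)c2cc1Cl)[C@@H]1CCCNC1`: 47 nM

In an assay on isolated protein for inhibition of Rho-associated protein kinase 2 (Homo sapiens), read by a luciferase reporter (a lower number here means a stronger inhibitor, a higher number a weaker inhibitor), compound 1 gives 120 nM, the highest of the two numbers. For the measured compounds named here, compound 2 gives 47 nM, and the single measured step is a 2.6-fold lower number from compound 1 to compound 2 (0.41 log units; beyond the scatter). Compound 3 `NC(C(=O)Nc1cc2cc[nH]c(=O)c2cc1Cl)c1cccc(Cl)c1` differs from compound 1 by 3-chlorophenyl in place of hydrogen on a saturated chain carbon bound to an amine nitrogen and a carbonyl carbon. Going by the values given here, only that one step bears on this change: it also enlarged the side chain bound to the carbonyl and lowered the number modestly, so a similar modest lowering, or none beyond the scatter, is expected. Compound 3 is therefore estimated at 70 nM, between 25 nM and 200 nM. This expected step is a 1.7-fold lower number from compound 1 to compound 3 (0.23 log units; within the scatter).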

Compound 3, half-maximal inhibitory concentration: 15 nM
Compound 3: the middle estimate sits 4.7-fold (0.67 log units) above what was measured; the measured number lies below the stated range.
By their numbers in this assay, from the lowest: compound 3; then compound 2; then compound 1.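

Replacing one hydrogen with 3-chlorophenyl on the saturated chain carbon bound to an amine nitrogen and a carbonyl carbon gives an 8.0-fold lower number from compound 1 to compound 3 (0.90 log units; beyond the scatter). The step from compound 1 to compound 2 replaced the whole aminomethyl group, whereas here the amine and carbonyl stay in place, so this carbon alone can carry an aromatic ring and the number still falls. Nothing measured here explains this fall. The compounds shown leave open how much of the step belongs to the ring and how much to its chlorine. A plain phenyl on the same carbon would separate the two, and a methyl there would test a much smaller group.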